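This account rests on a few compounds, and the source may have more. Where it says the series, first, only, none or still open, it means among the compounds named here.

Compound 1 `COc1ccccc1Cn1cc(CCc2cc(OC)c(OC)c(OC)c2)c2c(C)nc(N)nc21` gives 1000 nM in a functional assay on JC cells (Mus musculus) for inhibition, read by sulforhodamine B assay, with a stated time of 48 h; on this read-out lower numbers stand for stronger inhibition and higher numbers for weaker inhibition. Compound 2 `COc1ccc(Cn2cc(CCc3cc(OC)c(OC)c(OC)c3)c3c(C)nc(N)nc32)cc1` differs from it by 4-methoxyphenyl in place of 2-methoxyphenyl on a saturated chain carbon bound to an aromatic nitrogen; in this assay compound 2 gives 600 nM, a step of a 1.7-fold lower number from compound 1 to compound 2 (0.22 log units; within the scatter). Compound 3 `COc1ccccc1Cn1cc(Sc2ccccc2OC)c2c(C)nc(N)nc21` is built on a different core, and the difference between the two cores is not broken down here. In this assay compound 3 gives 9000 nM, the highest of the three numbers and beyond the scatter from both compound 1 and compound 2. Compound 4 `COc1ccc(Cn2cc(Sc3ccccc3OC)c3c(C)nc(N)nc32)cc1` differs from compound 3 by 4-methoxyphenyl in place of 2-methoxyphenyl on a saturated chain carbon bound to an aromatic nitrogen, the same change as between compound 1 and compound 2, occurring twice among these compounds. Among the measured compounds shown here, a step of similar size is expected, namely a 1.6-fold lower number from compound 3 to compound 4 (0.21 log units; within the scatter), because the only measured instance of this change was a 1.7-fold lower number from compound 1 to compound 2 (0.22 log units; within the scatter). Compound 4 is therefore expected near 5500 nM, between 2000 nM and 15000 nM.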

Compound 4, half-maximal inhibitory concentration: 2500 nM
For compound 4 the middle estimate is 2.2-fold (0.34 log units) above the measured one, and the stated range covers the measured number.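

In this assay, 4-methoxyphenyl in place of 2-methoxyphenyl on a saturated chain carbon bound to an aromatic nitrogen gives a 3.6-fold lower number from compound 3 to compound 4 (0.56 log units; beyond the scatter). The sizes of the steps on the two cores cannot be told apart, so the change carries over between these cores as far as the data can show: the same change on two cores in this assay, a 1.7-fold lower number (0.22 log units; within the scatter) from compound 1 to compound 2 and a 3.6-fold lower number (0.56 log units; beyond the scatter) from compound 3 to compound 4, 2.2-fold (0.33 log units) apart, within the scatter of two such steps. Among the compounds shown here, this rests on only two pairs in one assay, and only the step on the core of compound 3 lies beyond the scatter, so it sets no rule for other cores.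

Going by these compounds, it remains open how the number would respond to other groups at this place. An amine or a carboxylic acid in place of the methoxy group is one such case.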